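Swapping cyclohexyl for 4-methylphenyl on a ring amide nitrogen

The source may report more compounds than this note shows. Statements on the series, on what has been measured and on what is new or still open speak of the compounds shown alone.

Of the compounds shown here, three have so far been measured in a functional assay on A549 cells (Homo sapiens) for antiproliferative activity, read by MTT assay, with a stated time of 72 h; a higher number here means a weaker inhibitor, a lower number a stronger inhibitor. Compound 1 `COc1ncc(-c2ccc3c(c2)N(c2ccc(C)cc2)C(=O)CO3)cc1NS(=O)(=O)c1ccc(F)cc1` gives 5870 nM, compound 2 `COc1ncc(-c2ccc3c(c2)N(C2CCCCC2)C(=O)CO3)cc1NS(=O)(=O)c1ccc(F)cc1` gives 24600 nM, and compound 3 `O=C1COc2ccc(-c3cccc(NS(=O)(=O)c4ccc(F)cc4)c3)cc2N1C1CCCCC1` gives 14500 nM. Compound 2 and compound 3 differ in their cores, and that difference is not broken down here. Between compound 2 and compound 1 the change is 4-methylphenyl in place of cyclohexyl on an amide-type nitrogen in a ring, and it brought a 4.2-fold lower number from compound 2 to compound 1 (0.62 log units; beyond the scatter). Compound 4 `Cc1ccc(N2C(=O)COc3ccc(-c4cccc(NS(=O)(=O)c5ccc(F)cc5)c4)cc32)cc1` is not yet measured; it arises from compound 3 by the same change, (4-methylphenyl in place of cyclohexyl on an amide-type nitrogen in a ring), at the same place. Because the earlier step was a 4.2-fold lower number from compound 2 to compound 1 (0.62 log units; beyond the scatter), the step from compound 3 to compound 4 is expected to be of similar size, a 4.1-fold lower number from compound 3 to compound 4 (0.62 log units; beyond the scatter). Compound 4 is therefore estimated at about 3500 nM, likely between 1200 nM and 10000 nM.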

Compound 4, half-maximal inhibitory concentration: > 40000 nM
Compound 4 ended at the assay's limit; the forecaster's own chance of this, stated with the estimate: 5%; middle value at least 11-fold (1.05 log units) away from the limit.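

In this assay, 4-methylphenyl in place of cyclohexyl on the ring amide nitrogen did not carry over from one core to the other: it brought an at least 2.7-fold higher number from compound 3 to compound 4 (0.44 log units; beyond the scatter), opposite in direction to the earlier step, and the two steps differ: the same change on two cores in this assay, a 4.2-fold lower number (0.62 log units; beyond the scatter) from compound 2 to compound 1 and an at least 2.7-fold higher number (0.44 log units; beyond the scatter) from compound 3 to compound 4, at least 11-fold (1.06 log units) apart, beyond the scatter of two such steps Compound 4 gives > 40000 nM, which is a limit of the assay and not a number, so the full size of its step stays unknown: the limit of > 40000 nM in this assay, at which 1 of the 4 values shown sits. With one pair on each core, this shows that the outcome of the change differed between these two cores, but not why, nor what it would do on any other core.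

The compounds shown leave open whether a plain phenyl or a methyl on that nitrogen would follow compound 1 or compound 4. They also leave open which part of the difference between the two cores separates the two results.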